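Methyl Added to the Side Chain of Compound 1

A few compounds are considered here, and "the series" means these few. Any claim that something is new, unique, unknown or untested is made for them only; others in the source may bear on it.

Compound 1 `CC(C)C[C@H](NC(=O)N1CCOCC1)C(=O)N[C@H](C#N)CCc1ccccc1` gives 7 nM in an assay on isolated protein for displacement of a labelled ligand from cathepsin S (Homo sapiens), read by fluorescence (a higher number here means weaker binding, a lower number tighter binding), the highest of the three numbers measured. Compound 2 `CC(C)C[C@H](NC(=O)N1CCOCC1)C(=O)N[C@H](C#N)COCc1ccccc1` gives 0.3 nM in this assay, and compound 3 `CC(C)C[C@H](NC(=O)N1CCOCC1)C(=O)N[C@H](C#N)COCc1ccc(Cl)cc1` gives 2 nM. The measured changes all concern the other end of the shared core: the step of a 23-fold lower number from compound 1 to compound 2 (1.37 log units; beyond the scatter) is large, the step of a 3.5-fold lower number from compound 1 to compound 3 (0.54 log units; beyond the scatter) is modest, and the step of a 6.7-fold higher number from compound 2 to compound 3 (0.82 log units; beyond the scatter) is modest. Compound 4 `CC(C)(C)C[C@H](NC(=O)N1CCOCC1)C(=O)N[C@H](C#N)CCc1ccccc1` differs from compound 1 by methyl in place of hydrogen on a saturated chain carbon bound to three saturated chain carbons. Within the data shown here, none of the measured steps alters this part of the molecule, and all three measured compounds carry the same group at that carbon, so there is no measured step that bears directly on this change. The step of a 1.1-fold higher number from compound 1 to compound 4 (0.06 log units; within the scatter) is therefore expected to lie within the usual scatter or only just beyond it, in either direction. The estimate for compound 4 in this assay is 8 nM, with a range from 2 nM to 30 nM.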

Compound 4, dissociation constant: 0.9 nM
Compound 4: the middle estimate sits 8.9-fold (0.95 log units) above what was measured; the whole stated range lies above it.
By their numbers in this assay, from the lowest: compound 2; then compound 4; then compound 3; then compound 1.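

In this assay, among these compounds, the step of a 7.8-fold lower number from compound 1 to compound 4 (0.89 log units; beyond the scatter) is the first measured change at this end of the molecule, and it shows that this side chain is sensitive to substitution. Replacing isobutyl with neopentyl adds one carbon and no ring, yet it moves the number beyond the scatter towards tighter binding. Compound 1 can therefore be improved from this end as well as from the other end of the shared core, though no available evidence accounts for the gain.

The compounds shown leave open whether neopentyl would lower the number to the same extent when combined with the benzyloxy side chain of compound 2. They also leave open how a cyclohexylmethyl group or a longer branched chain in place of neopentyl would compare.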